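Removing One Methoxy Group: What to Expect

The source may report more compounds than this note shows. Statements on the series, on what has been measured and on what is new or still open speak of the compounds shown alone.

Of the compounds shown here, three have been measured in a functional assay on NCI/ADR-RES cells (Homo sapiens) for cytotoxicity, read by sulforhodamine B assay, with a stated time of 48 h, tested at 100 uM; on this read-out higher numbers stand for a weaker effect at the one concentration tested and lower numbers for a stronger effect. Compound 1 `COc1ccc(-c2cc(/C=C/C(=O)c3ccc(N)cc3)[nH]n2)cc1` gives -38%, compound 2 `COc1cc(-c2cc(/C=C/C(=O)c3ccc(N)cc3)[nH]n2)cc(OC)c1OC` gives -3%, and compound 3 `COc1ccc(C(=O)/C=C/c2cc(-c3cc(OC)c(OC)c(OC)c3)n[nH]2)cc1OC` gives -40%. Compound 2 stands highest of the three, that is, it shows the weakest effect; both compound 1 and compound 3 lie beyond the scatter below it.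

Compound 4 `COc1ccc(-c2cc(/C=C/C(=O)c3ccc(N)cc3)[nH]n2)cc1OC` differs from compound 2 in one place: hydrogen in place of methoxy on an aromatic carbon. Within the data shown here, the measured step that comes closest is the one from compound 2 to compound 3 in this assay, which was a number 37 percentage points lower from compound 2 to compound 3 (beyond the scatter), but that step changed the group on the carbonyl carbon, not a methoxy group, so it bears only loosely on the present change. Compound 1, which carries a single methoxy group on the same ring, sits far below compound 2, and compound 4 with two methoxy groups lies between those two structures.

On that basis compound 4 is expected to fall below compound 2, with the step from compound 2 to compound 4 in this assay estimated at a number 19 percentage points lower from compound 2 to compound 4 (beyond the scatter). The estimate for compound 4 in this assay is -22%, expected to lie between -42% and -2%.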

Compound 4, a percentage reported as activity, at one concentration (the size of the read-out at that concentration, not a potency): 2%
For compound 4 the middle estimate is 24 percentage points below the measured one; measured number outside the range, above it.
By their numbers in this assay, from the lowest: compounds 3 and 1 (each within the scatter of the next); then compounds 2 and 4 (each within the scatter of the next).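

On the six-membered aromatic ring that carries the methoxy groups, removing one methoxy group from compound 2 barely registers in this assay: the result is a number 5 percentage points higher from compound 2 to compound 4 (within the scatter). The same kind of change read in the other direction, methoxy in place of hydrogen on an aromatic carbon of compound 1, is large, with a number 40 percentage points higher from compound 1 to compound 4 (beyond the scatter), so the size of the effect of a methoxy group here depends on which other methoxy groups the ring already carries, at least across compounds 1, 2 and 4. No supporting measurement is available to explain why this swap matters so much in one setting and so little in the other.

From the compounds shown here alone, it remains open whether a hydroxyl group, a chlorine atom or an amine on this aromatic carbon would give a number like that of hydrogen or like that of methoxy. Also open, going by these compounds, is whether the same dependence holds when the 3,4-dimethoxyphenyl group of compound 3 replaces the 4-aminophenyl group on the carbonyl carbon, and whether it would persist at other concentrations, since each number here comes from a single one.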